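Para Halogen Exchange on the Benzylamine Arm

The source may hold more compounds than are shown below. What is called first, only, known or untested is meant among the compounds shown, and "the series" means these compounds.

Among the measured compounds shown here, in an assay on a protein complex for inhibition of ubiquitin carboxyl-terminal hydrolase 1/WD repeat-containing protein 48 (Homo sapiens), read by fluorescence (on this read-out lower numbers stand for stronger inhibition and higher numbers for weaker inhibition), compound 2 `Fc1ccc(CNc2nc(-c3ccccc3C(F)(F)F)nc3ccccc23)cc1` gives 3400 nM, the higher of the two numbers measured so far, with compound 1 `FC(F)(F)c1ccccc1-c1nc(NCc2ccccc2)c2ccccc2n1` as its nearest neighbour at 3100 nM, a difference within the scatter. For the measured compounds named here, the only measured step, a 1.1-fold higher number from compound 1 to compound 2 (0.04 log units; within the scatter), covers fluoro in place of hydrogen on an aromatic carbon of the benzylamine arm. Compound 3 `FC(F)(F)c1ccccc1-c1nc(NCc2ccc(Cl)cc2)c2ccccc2n1` differs from compound 2 by chloro in place of fluoro on an aromatic carbon. Going by the values given here, no measured step covers chloro in place of fluoro, so the expectation rests on the observation that placing fluoro at this position left this assay unchanged beyond the scatter. On that basis the step from compound 2 to compound 3 is expected to be small, a 1.4-fold lower number from compound 2 to compound 3 (0.13 log units; within the scatter), with at most a slight lowering of the number. Compound 3 is therefore estimated at 2500 nM, in a range from 1000 nM to 6500 nM.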

Compound 3, half-maximal inhibitory concentration: 4800 nM
Compound 3: middle estimate off by 1.9-fold (0.28 log units), on the low side; low and high end bracket the measured number.
By their numbers in this assay, from the lowest: compounds 1, 2 and 3 (each within the scatter of the next).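

The benzylamine arm now carries three different substituents at this place, para to a large group, and chloro stays within the scatter of both others in this assay: a 1.4-fold higher number from compound 2 to compound 3 (0.15 log units; within the scatter) and a 1.5-fold higher number from compound 1 to compound 3 (0.19 log units; within the scatter). Compound 1, compound 2 and compound 3 therefore cannot be told apart on this read-out, whereas the earlier pair had shown this only for fluoro against hydrogen. No further measurement bears on why these exchanges leave the number within the scatter. From the compounds shown here alone, whether a different kind of group at this place, such as a methoxy group, an amine or a carboxylic acid, would move the number beyond the scatter stays open. So does whether chloro on another carbon of this ring, or a longer chain in place of the benzyl arm, would do so.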